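Chloro in Place of Methoxy: Expectation for Compound 4

A few compounds are considered here, and "the series" means these few. Any claim that something is new, unique, unknown or untested is made for them only; others in the source may bear on it.

Measured compounds:
compound 1, `COc1cc(/C=C/C(=O)c2cccc(-n3cc(-c4ccccc4)[nH]c3=O)c2)ccc1O`, 3760 nM
compound 2, `O=C(/C=C/c1cccc(O)c1)c1cccc(-n2cc(-c3ccc(Cl)cc3)[nH]c2=O)c1`, 4210 nM
compound 3, `COc1ccc(-c2cn(-c3cccc(C(=O)/C=C/c4ccc(O)c(OC)c4)c3)c(=O)[nH]2)cc1`, 4770 nM

In a functional assay on SK-OV-3 cells (Homo sapiens) for inhibition (a lower number here means a stronger inhibitor of growth, a higher number a weaker inhibitor of growth), compound 3 gives the highest of the three numbers, yet it lies within the scatter of compound 2 and of compound 1 alike, so no order among them can be claimed. Compound 4, `COc1cc(/C=C/C(=O)c2cccc(-n3cc(-c4ccc(Cl)cc4)[nH]c3=O)c2)ccc1O`, differs from compound 3 by chloro in place of methoxy on an aromatic carbon. Among the compounds with values here, the one measured step that changes a single place, a 1.3-fold higher number from compound 1 to compound 3 (0.10 log units; within the scatter), stayed within the scatter. Compound 2 also carries the chloro group but differs from compound 3 in a second place too, and its value and that of compound 3 show no separation beyond the scatter. Compound 4 is therefore expected to show no step beyond the scatter, estimated at 4200 nM with a range of 2100 nM to 8400 nM.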

Compound 4, concentration for 50% growth inhibition: 3190 nM
Estimate against measurement, compound 4: 1.3-fold (0.12 log units) above; the range from low to high includes it.
By their numbers in this assay, from the lowest: compounds 4, 1, 2 and 3 (each within the scatter of the next).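

In this assay, the change from 4-methoxyphenyl to 4-chlorophenyl gives a 1.5-fold lower number from compound 3 to compound 4 (0.17 log units; within the scatter), and chloro in place of hydrogen at the same place gives a 1.2-fold lower number from compound 1 to compound 4 (0.07 log units; within the scatter). Hydrogen, methoxy and chloro on this aromatic carbon thus do not separate on this background. A change in a different place, 4-hydroxy-3-methoxyphenyl in place of 3-hydroxyphenyl, gives a 1.3-fold lower number from compound 2 to compound 4 (0.12 log units; within the scatter). No evidence is available on what lies behind these numbers. On these data alone, whether an amine or a carboxylic acid on this aromatic carbon would give a step beyond the scatter remains open.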